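The compounds below may be only part of what the source reports. "The series", "measured", "known", "first", "only" and "open" are said of these compounds alone.

The shared core is that of compound 1 `CC1(C)C=C(n2ccccc2=O)c2ccccc2O1`, which in a functional assay (trachea) with Rattus norvegicus as the target (a lower number here means a less potent compound, a higher number a more potent compound, by a factor of ten per unit of this negative logarithm), gives 5.05. Compound 2 `CC(=O)c1ccc2c(c1)C(n1ccccc1=O)=CC(C)(C)O2` gives 6.65, and compound 3 `CC1(C)C=C(n2ccccc2=O)c2cc(C=O)ccc2O1` gives 6.14. Compound 3 thus stands second highest of the three numbers: compound 2 is nearest, the step being a number 0.51 log units lower from compound 2 to compound 3 (beyond the scatter), and compound 1 is furthest, the step being a number 1.09 log units higher from compound 1 to compound 3 (beyond the scatter).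

Compound 4 `CC1(C)C=C(n2ccccc2=O)c2cc(Br)ccc2O1` differs from compound 3 in one place: bromo in place of formyl on an aromatic carbon. For the measured compounds named here, no measured step exchanges formyl for bromo, so only indirect bearings exist. The formyl is worth a number 1.09 log units higher from compound 1 to compound 3 (beyond the scatter), the acetyl a number 1.60 log units higher from compound 1 to compound 2 (beyond the scatter), and trimming acetyl to formyl costs a number 0.51 log units lower from compound 2 to compound 3 (beyond the scatter). Whether bromo retains any of the gain over hydrogen is not shown by these data. Compound 4 is therefore expected to land between compound 1 and compound 3, a step of a number 0.54 log units lower from compound 3 to compound 4 (beyond the scatter), with wide uncertainty. The estimate for compound 4 in this assay is 5.6, with a range from 4.9 to 6.4.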

Compound 4, logarithm of the reciprocal of the active concentration, log(1/C): 7.53
Beside the measured number, compound 4's estimate is 1.93 log units below it, outside the stated range (above it).
By their numbers in this assay, from the lowest: compound 1; then compound 3; then compound 2; then compound 4.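

In this assay a carbonyl group is not required for the gain at this aromatic carbon: bromo, which enters with no hydrogen-bond acceptor, gives a number 2.48 log units higher from compound 1 to compound 4 (beyond the scatter) over hydrogen, a larger gain than formyl or acetyl gives. Exchanging the carbonyl groups for bromo raises the number further, with a number 1.39 log units higher from compound 3 to compound 4 (beyond the scatter) for formyl and a number 0.88 log units higher from compound 2 to compound 4 (beyond the scatter) for acetyl, which places compound 4 highest of the four, with every step to it beyond the scatter. No measurement available here bears on what lies behind this order of substituents.

Going by these compounds, whether the gain is particular to bromo or extends to chloro, iodo or a nitrile on this aromatic carbon remains open. Also open, on these data alone, is whether bromo would hold its standing on the other aromatic carbons of that ring.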